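Adding a Third Fluorine to the Phenoxy Group

A few compounds are considered here, and "the series" means these few. Any claim that something is new, unique, unknown or untested is made for them only; others in the source may bear on it.

Compound 1 `CC(C)[C@H](NC(=O)COc1cccc2ccccc12)C(=O)N[C@@H](CC(=O)O)C(=O)COc1ccccc1F`: 15700 nM
Compound 2 `CC(C)[C@H](NC(=O)COc1cccc2ccccc12)C(=O)N[C@@H](CC(=O)O)C(=O)COc1cc(F)ccc1F`: 19700 nM

Both compounds share one core and were tested in a functional assay with Homo sapiens as the target; a higher number here means a weaker inhibitor, a lower number a stronger inhibitor. Compound 2 stands alongside compound 1: the step of a 1.3-fold higher number from compound 1 to compound 2 (0.10 log units; within the scatter) lies within the scatter, so the two numbers cannot be told apart, and neither compound can be called the stronger inhibitor.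

Compound 3 `CC(C)[C@H](NC(=O)COc1cccc2ccccc12)C(=O)N[C@@H](CC(=O)O)C(=O)COc1c(F)cc(F)cc1F` has not yet been measured. It differs from compound 2 in one place: 2,4,6-trifluorophenyl in place of 2,5-difluorophenyl on an oxygen on a saturated carbon. For the measured compounds named here, the only measured step that bears on this change is a 1.3-fold higher number from compound 1 to compound 2 (0.10 log units; within the scatter), which also put fluoro in place of hydrogen on an aromatic carbon and moved the number by no more than the scatter. A further fluorine on the same ring is therefore expected to leave the number roughly where it is, perhaps nudging it upward; the expected step is a 1.2-fold higher number from compound 2 to compound 3 (0.07 log units; within the scatter). Compound 3 is estimated at 23000 nM, within a range from 9000 nM to 60000 nM.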

Compound 3, half-maximal inhibitory concentration: 14900 nM
Estimate against measurement, compound 3: 1.5-fold (0.19 log units) above; measured number inside the range.
By their numbers in this assay, from the lowest: compounds 3, 1 and 2 (each within the scatter of the next).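

In this assay, putting 2,4,6-trifluorophenyl in place of 2,5-difluorophenyl on the oxygen gives a 1.3-fold lower number from compound 2 to compound 3 (0.12 log units; within the scatter) and, in place of 2-fluorophenyl, gives a 1.1-fold lower number from compound 1 to compound 3 (0.02 log units; within the scatter) at the same position. Compound 1, compound 2 and compound 3 therefore cannot be told apart, so neither of the new steps separates any of the three. For the compounds shown here, the earlier pair covered only the step from 2-fluorophenyl to 2,5-difluorophenyl, whereas this result shows that a ring with a different fluorine pattern also stays within the scatter.

Going by these compounds, whether a plain phenyl without fluorine, or a ring carrying a chloro or methoxy group, would stay within the scatter of these numbers remains open. Nothing available explains why these three rings cannot be told apart.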